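Amide-linked series: ester to acid step ahead of measurement

The source may report more compounds than this note shows. Statements on the series, on what has been measured and on what is new or still open speak of the compounds shown alone.

Measured so far:
compound 1 `O=C(O)CCCN1CCC(COC(=O)c2c[nH]c3ccccc23)CC1` — 0.813 nM
compound 2 `CCOC(=O)CCCN1CCC(CNC(=O)c2c[nH]c3ccccc23)CC1` — 107 nM

In a functional assay on HEK293 cells for antagonist activity at 5-hydroxytryptamine receptor 4 (Homo sapiens) (on this read-out higher numbers stand for weaker inhibition and lower numbers for stronger inhibition), compound 2 gives 107 nM, the highest of the two numbers; compound 1 gives 0.813 nM, a gap well beyond the scatter, though the two structures differ in more than one place. Compound 3 `O=C(O)CCCN1CCC(CNC(=O)c2c[nH]c3ccccc23)CC1` carries the change (hydrogen in place of ethyl on an oxygen next to a carbonyl group), hydrogen in place of ethyl on an oxygen next to a carbonyl group. For the measured compounds named here, no single step between measured compounds calibrates this. A lower number is nevertheless expected for compound 3, since the carboxy form is shared with compound 1, which gives 0.813 nM. The expected step of an 11-fold lower number from compound 2 to compound 3 (1.03 log units; beyond the scatter) lies beyond the scatter. Compound 3 is estimated at 10 nM, range 2 nM to 60 nM.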

Compound 3, inhibition constant: 3630 nM
Beside the measured number, compound 3's estimate is 360-fold (2.56 log units) below it; measured number above the stated range.
By their numbers in this assay, from the lowest: compound 1; then compound 2; then compound 3.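

In this assay, for the compounds shown here, hydrogen in place of ethyl on an oxygen next to a carbonyl group gives a 34-fold higher number from compound 2 to compound 3 (1.53 log units; beyond the scatter), the first single-place step in this amide-linked series, and here the ethoxycarbonyl form is favoured over the carboxy form. The carboxy group does not by itself bring a low number: compound 1 gives 0.813 nM and compound 3, with the same carboxy end, gives 3630 nM in this assay. No measurement at hand accounts for this step. Open, on these data alone, is how a primary amide or a longer chain carrying the carboxylic acid would read in the amide-linked series.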